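The source may hold more compounds than are shown below. What is called first, only, known or untested is meant among the compounds shown, and "the series" means these compounds.

Working notes on the series. Within the data shown here, in a functional assay on MCF7 cells (Homo sapiens) for cytotoxicity, read by MTT assay, with a stated time of 72 h (a higher number here means a weaker inhibitor, a lower number a stronger inhibitor), compound 3 `Cc1cc(=O)n(-c2ccccc2OC(F)(F)F)nc1C(=O)Nc1ccc(Oc2ncnc3[nH]ccc23)c(F)c1` gives 11700 nM, the second highest of the three numbers so far: compound 2 `Cc1cc(=O)n(-c2ccc(F)cc2)nc1C(=O)Nc1ccc(Oc2ncnc3[nH]ccc23)c(F)c1` gives 24500 nM, and compound 1 `Cc1cc(=O)n(-c2ccc(Br)cc2F)nc1C(=O)Nc1ccc(Oc2ncnc3[nH]ccc23)cc1` gives 3210 nM. Among the measured compounds shown here, the only step measured within this set is a 2.1-fold lower number from compound 2 to compound 3 (0.32 log units; beyond the scatter). The next compound, compound 4 `Cc1cc(=O)n(-c2ccc(Br)cc2F)nc1C(=O)Nc1ccc(Oc2ncnc3[nH]ccc23)c(F)c1`, differs from compound 3 by 4-bromo-2-fluorophenyl in place of 2-(trifluoromethoxy)phenyl on an aromatic nitrogen. For the measured compounds named here, no measured step covers this exchange directly; compound 1, which carries the same 4-bromo-2-fluorophenyl group on a closely related core, is the only pointer, and its value lies below that of compound 3. A moderate move downward in this assay is therefore expected, of about a 2.6-fold lower number from compound 3 to compound 4 (0.41 log units; beyond the scatter). For compound 4 the expected value is 4500 nM, with a range of 1500 nM to 14000 nM.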

Compound 4, half-maximal inhibitory concentration: 26600 nM
The estimate for compound 4 lay 5.9-fold (0.77 log units) below the measured number, outside the stated range (above it).
By their numbers in this assay, from the lowest: compound 1; then compound 3; then compounds 2 and 4 (each within the scatter of the next).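

In this assay, among these compounds, the largest step so far lies on the aromatic carbon of the core, where fluoro replaces hydrogen with 4-bromo-2-fluorophenyl held constant (an 8.3-fold higher number from compound 1 to compound 4 (0.92 log units; beyond the scatter)). On the aromatic nitrogen, 4-bromo-2-fluorophenyl compares poorly with 2-(trifluoromethoxy)phenyl (a 2.3-fold higher number from compound 3 to compound 4 (0.36 log units; beyond the scatter)), and this assay does not separate it from 4-fluorophenyl (a 1.1-fold higher number from compound 2 to compound 4 (0.04 log units; within the scatter)). Nothing available explains these steps. Open, from the compounds shown here alone, is whether the fluoro step holds with other groups on the aromatic nitrogen, and how a phenyl ring bearing an amine or a carboxylic acid would read there.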